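Chloro in Place of Bromo on the Fused Ring

The compounds below may be only part of what the source reports. "The series", "measured", "known", "first", "only" and "open" are said of these compounds alone.

Compound 1 `CN(C)c1ccc(C2CC(c3ccccc3)=NN2C2=NC(=O)/C(=C3\C(=O)Nc4ccccc43)S2)cc1` gives 39700 nM in a functional assay on cells (Cancer cell lines, Homo sapiens) for cytotoxicity, read by sulforhodamine B assay, with a stated time of 48 h; a lower number here means a stronger inhibitor of growth, a higher number a weaker inhibitor of growth. Compound 2 `CN(C)c1ccc(C2CC(c3ccccc3)=NN2C2=NC(=O)/C(=C3\C(=O)Nc4ccc(Br)cc43)S2)cc1` gives 690 nM in this assay, and the step of a 58-fold lower number from compound 1 to compound 2 (1.76 log units; beyond the scatter) is the only one measured here. Compound 2 therefore stands at the lower of the two numbers, with compound 1 the nearest neighbour and well beyond the scatter above it.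

Compound 3 `CN(C)c1ccc(C2CC(c3ccccc3)=NN2C2=NC(=O)/C(=C3\C(=O)Nc4ccc(Cl)cc43)S2)cc1` differs from compound 2 by chloro in place of bromo on an aromatic carbon. The measured step of a 58-fold lower number from compound 1 to compound 2 (1.76 log units; beyond the scatter) bears on this only indirectly: it shows what a halogen entering where hydrogen stood did, not what one halogen replacing another does. With compound 3 keeping a halogen at the same place, a step in this assay of small size or none beyond the scatter is expected. Compound 3 is estimated at 1000 nM, with a range from 300 nM to 3500 nM, which would amount to an expected step of a 1.4-fold higher number from compound 2 to compound 3 (0.16 log units; within the scatter).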

Compound 3, concentration for total growth inhibition: 620 nM
Estimate against measurement, compound 3: 1.6-fold (0.21 log units) above; the measured number falls inside the stated range.
By their numbers in this assay, from the lowest: compounds 3 and 2 (each within the scatter of the next); then compound 1.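

In this assay, chloro in place of bromo on this aromatic carbon gives a 1.1-fold lower number from compound 2 to compound 3 (0.05 log units; within the scatter), so the two halogens cannot be told apart at this place. Chloro in place of hydrogen gives a 64-fold lower number from compound 1 to compound 3 (1.81 log units; beyond the scatter), which shows that the large step first seen with bromo is not unique to bromo but appears with both halogens, in compound 2 and compound 3. Nothing offered here accounts for either step or for the likeness of the two halogens.

Going by these compounds, it remains open whether fluoro, iodo or another group that is not a halogen, such as methoxy, nitro or an amine, would give a step of similar size at this same place. On these data alone, it is also open whether a halogen here would have the same effect with the dimethylamino group on the shared core replaced by a carboxylic acid.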